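This account rests on a few compounds, and the source may have more. Where it says the series, first, only, none or still open, it means among the compounds named here.

In a physicochemical assay for lipophilicity (a higher number here means a more lipophilic compound, a lower number a more polar compound), compound 1 (`CC(O)(C(=O)Nc1ccc([N+](=O)[O-])c(C(F)(F)F)c1)C(F)(F)F`) gives 3.21, and compound 2 (`CC(O)(C(=O)Nc1ccc([N+](=O)[O-])c(C(F)(F)F)c1)C(F)F`) gives 3.76, the higher of the two numbers. Compound 3 (`CC(O)(CF)C(=O)Nc1ccc([N+](=O)[O-])c(C(F)(F)F)c1`) differs from compound 2 by hydrogen in place of fluoro on a saturated chain carbon bound to a fluorine atom and a saturated chain carbon: difluoromethyl to fluoromethyl. Among the measured compounds shown here, only one measured step bears on this, a number 0.55 log units higher from compound 1 to compound 2 (beyond the scatter), which is the same kind of replacement on a carbon bound to two fluorine atoms. As far as these compounds go, a single step fixes no trend, so the direction stays open and no change beyond the scatter is expected. The expected step is a number 0.06 log units lower from compound 2 to compound 3 (within the scatter). Compound 3 is estimated at 3.7, with a range of 3.25 to 4.15.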

Compound 3, partition coefficient: 3.5
The estimate for compound 3 lay 0.20 log units above the measured number; the measured number falls inside the stated range.
By their numbers in this assay, from the lowest: compounds 1, 3 and 2 (each within the scatter of the next, the first and the last beyond it).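

At this position, in this assay, the further hydrogen-for-fluoro replacement, difluoromethyl to fluoromethyl, gives a number 0.26 log units lower from compound 2 to compound 3 (within the scatter), whereas the earlier replacement gave a number 0.55 log units higher from compound 1 to compound 2 (beyond the scatter), beyond the scatter. Fluoromethyl in place of trifluoromethyl gives a number 0.29 log units higher from compound 1 to compound 3 (within the scatter), so the size of the step does not follow the fluorine count evenly across these three compounds. Nothing measured here gives a reason for these steps. As far as these compounds go, whether a plain methyl group at this place would fit with these numbers stays open, as does the reading for a longer chain or an amine there.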